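A few compounds are considered here, and "the series" means these few. Any claim that something is new, unique, unknown or untested is made for them only; others in the source may bear on it.

Compound 1 `CN(C)c1ccc(C#Cc2c(F)cccc2F)nc1` gives 15.1% in a functional assay on LS174T cells (Homo sapiens) for inhibition, with a stated time of 4 days, tested at 100 nM; on this read-out higher numbers stand for a stronger effect at the one concentration tested and lower numbers for a weaker effect. Compound 2 `CN(C)c1ccc(C#Cc2c(F)cccc2F)cn1` gives 0% in this assay.

Of these two numbers, compound 2 holds the lower one: compound 1 gives the higher reading, and the gap between the two lies beyond the usual scatter of such measurements. Both share the same core, a six-membered aromatic ring with one nitrogen carrying a dimethylamino group; they differ only in where the ring nitrogen sits.

Compound 3 `Fc1cccc(F)c1C#Cc1ccc(-n2cccc2)nc1` keeps the ring pattern of compound 2 and changes the group itself: 1H-pyrrol-1-yl in place of dimethylamino on an aromatic carbon. Among the measured compounds shown here, no measured pair shows what this kind of exchange does in this assay, so the size of the step can only be guessed. The expected step from compound 2 to compound 3 is small, a number 5 percentage points higher from compound 2 to compound 3 (within the scatter), not clearly beyond the scatter. Compound 3 is therefore estimated at 5%, with a range from 0% to 25%.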

Compound 3, a percentage reported as inhibition, at one concentration (the size of the read-out at that concentration, not a potency): 0%
The estimate for compound 3 lay 5 percentage points above the measured number; the range from low to high includes it.
By their numbers in this assay, from the lowest: compounds 2 and 3 (each within the scatter of the next); then compound 1.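

In this assay, replacing dimethylamino with the larger, ring-bearing 1H-pyrrol-1-yl on this aromatic carbon, next to the ring nitrogen, gives no change at the digits printed from compound 2 to compound 3 (within the scatter) and so leaves the reading unchanged. Among the compounds shown here, this is the first direct test of the group at this place, and it shows that adding a five-membered aromatic ring there brings no measurable inhibition at the one concentration tested. Compound 2 already gives 0% before the exchange, so this pair cannot show whether the new group would weaken an effect, and no measurement here offers an explanation for the result.

On these data alone, it remains open whether a primary amine, a methoxy group or a morpholine ring at this place would raise the reading. For the compounds shown here, also open is how 1H-pyrrol-1-yl would behave on the core of compound 1, which gives the only clearly non-zero reading here.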